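Fluoro in Place of Chloro: From Compound 1 to Compound 3

This account rests on a few compounds, and the source may have more. Where it says the series, first, only, none or still open, it means among the compounds named here.

For the measured compounds named here, compound 1 `COc1cc(OC)c(C(=O)/C=C/c2ccc(Cl)cc2)c(OC)c1` is the only member of this small set with a reported number. In a functional assay on MDA-MB-231 cells (Homo sapiens), read by fluorescence and BrdU incorporation, with a stated time of 48 h, tested at 10 uM (on this read-out higher numbers stand for a weaker effect at the one concentration tested and lower numbers for a stronger effect), compound 1 gives 39%. Going by the values given here, compound 2 `COc1cc(O)c(C(=O)/C=C/c2ccccc2SC)c(OC)c1` is reported in this assay as "not active" (no number reported), with no figure behind it, so no step between measured compounds is available to lean on. Compound 3 `COc1cc(OC)c(C(=O)/C=C/c2ccc(F)cc2)c(OC)c1` differs from compound 1 in one place: fluoro in place of chloro on an aromatic carbon. With a single number to go on, any expectation rests on compound 1 alone. The exchange of fluoro for chloro is expected to shift the read-out only modestly, and the step is estimated at a number 9 percentage points higher from compound 1 to compound 3 (within the scatter), which is expected to stay within the ordinary scatter of this kind of measurement. Compound 3 is therefore expected to give about 48% in this assay, with a range from 30% to 72%.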

Compound 3, a percentage reported as activity, at one concentration (the size of the read-out at that concentration, not a potency): 43%
Compound 3: middle estimate off by 5 percentage points, on the high side; the measured number falls inside the stated range.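

In this assay the exchange of chloro for fluoro gives a number 4 percentage points higher from compound 1 to compound 3 (within the scatter) and so sets the two halogens level on this read-out. For the compounds shown here, this is the only pair in the set that differs in one place, and it shows that this position, para to a large group, takes fluoro as well as chloro without a difference beyond the scatter. No available evidence explains why the two compounds read alike.

Both groups are single halogen atoms, so the compounds shown leave open how the read-out responds at this place to an amine, a carboxylic acid or a bare hydrogen. Compound 2 has no number and differs from compound 1 and compound 3 in more than one place, so it adds nothing to this comparison.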